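Capping a hydroxy group on the aryl ether series

A few compounds are considered here, and "the series" means these few. Any claim that something is new, unique, unknown or untested is made for them only; others in the source may bear on it.

compound 1 `Cc1occc1-c1nn2c(-c3ccncc3)nnc2s1` - 61.6%
compound 2 `Fc1ccc(OCc2nn3c(-c4ccncc4)nnc3s2)cc1` - 48.3%
compound 3 `Oc1ccc(OCc2nn3c(-c4ccncc4)nnc3s2)cc1` - 56.2%

In a functional assay on BHK-21 cells (Mesocricetus auratus) for antiproliferative activity, read by sulforhodamine B assay, with a stated time of 48 h, tested at 10 uM (on this read-out lower numbers stand for less inhibition of growth and higher numbers for more inhibition of growth at the one concentration tested), compound 3 gives 56.2% and sits within the usual scatter of both compound 1 and compound 2, so these few numbers do not rank it firmly against either.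

The next compound is compound 4 `COc1ccc(OCc2nn3c(-c4ccncc4)nnc3s2)cc1` and it keeps the shared core. The change is methyl in place of hydrogen on an oxygen on an aromatic ring in which methyl takes the place of hydrogen on an oxygen on an aromatic ring, turning hydroxy into methoxy.

Within the data shown here, only one measured step touches this group. The step of a number 7.9 percentage points higher from compound 2 to compound 3 (within the scatter) swaps fluoro for hydroxy, and it stayed within the scatter. Among the measured compounds shown here, no measured step caps a hydroxy group, so this is indirect evidence. It gives no reason to expect a shift beyond the scatter in this assay and no firm direction.

The expected step is small, a number 3.2 percentage points lower from compound 3 to compound 4 (within the scatter) and within the scatter. For compound 4 the estimated value is 53% with an expected range from 40% to 66%.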

Compound 4, percent growth inhibition at one concentration: 71.9%
Beside the measured number, compound 4's estimate is 18.9 percentage points below it; the measured number lies above the stated range.
By their numbers in this assay, from the lowest: compounds 2, 3 and 1 (each within the scatter of the next, the first and the last beyond it); then compound 4.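

Methyl on this oxygen gives a number 15.7 percentage points higher from compound 3 to compound 4 (beyond the scatter) in this assay, so a single added carbon at this place is enough to shift the read-out by more than the usual scatter. Methoxy also separates from fluoro at the same ring carbon, with a number 23.6 percentage points higher from compound 2 to compound 4 (beyond the scatter) on record, while hydroxy and fluoro had not separated from each other. This makes the group on this ring carbon a place where the read-out responds to a small change, but nothing measured here explains why the methyl has this effect.

On these data alone, it remains open whether this rise is particular to methoxy or extends to larger groups on this oxygen, such as ethoxy or a longer chain. An amine or a carboxylic acid at the same ring carbon would also test how far the result depends on having an oxygen there.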